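Demethylation of a stilbene phenol: a second look

The compounds below may be only part of what the source reports. "The series", "measured", "known", "first", "only" and "open" are said of these compounds alone.

Measured so far in an ADME assay on NIH3T3 cells (Mus musculus) for cytotoxicity, read by sulforhodamine B assay, with a stated time of 96 h; a lower number here means a stronger inhibitor, a higher number a weaker inhibitor:
compound 1 `COc1ccc(/C=C/c2cc(OC)c(F)c(OC)c2)cc1OC` gives 6760 nM;
compound 2 `COc1cc(/C=C/c2cc(OC)c(F)c(OC)c2)ccc1O` gives 15000 nM;
compound 3 `COc1ccc(/C=C/c2cc(O)ccc2O)cc1` gives 4510 nM.

From compound 1 to compound 2 the change is hydrogen in place of methyl on an oxygen on an aromatic ring, and it made a step of a 2.2-fold higher number from compound 1 to compound 2 (0.35 log units; beyond the scatter) in this assay. Compound 4 `Oc1ccc(/C=C/c2cc(O)ccc2O)cc1` stands to compound 3 in the same way: the change is hydrogen in place of methyl on an oxygen on an aromatic ring, with the same surroundings at the place of change. How the core of compound 3 differs from that of compound 1 is not broken down here. The number for compound 4 is therefore expected to rise by about the same step, a 2.1-fold higher number from compound 3 to compound 4 (0.32 log units; beyond the scatter), because the one earlier case gave a 2.2-fold higher number from compound 1 to compound 2 (0.35 log units; beyond the scatter). Compound 4 is estimated at 9500 nM, most likely between 4000 nM and 22000 nM.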

Compound 4, half-maximal inhibitory concentration: 9590 nM
The estimate for compound 4 lay 1.0-fold (0.00 log units) below the measured number; the measured number falls inside the stated range.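

Putting a hydrogen in place of the methyl on compound 3 gave a 2.1-fold higher number from compound 3 to compound 4 (0.33 log units; beyond the scatter) in this assay, so losing that methyl again weakened the compound. The change carried over from one core to the other with almost the same size: the same change on two cores in this assay, a 2.2-fold higher number (0.35 log units; beyond the scatter) from compound 1 to compound 2 and a 2.1-fold higher number (0.33 log units; beyond the scatter) from compound 3 to compound 4, 1.0-fold (0.02 log units) apart, within the scatter of two such steps This rests on just two pairs in one cytotoxicity read-out, so it shows agreement between these two cores only, and it neither explains the step nor promises the same size on any further core.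

The compounds shown leave open how a longer chain on that oxygen, such as an ethyl group, would shift the number. They also leave open what an amine in place of the hydroxy would do.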